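From Fluoro to Chloro in a Cell Toxicity Test

A few compounds are considered here, and "the series" means these few. Any claim that something is new, unique, unknown or untested is made for them only; others in the source may bear on it.

Compound 1 `CN1CCN(CCCOc2ccc(N3C(=O)S/C(=C\c4ccc(Oc5ccc(C#N)cc5)cc4)C3=O)cc2)CC1`: > 10000 nM
Compound 2 `CN1CCN(CCCCCOc2cccc(N3C(=O)S/C(=C\c4ccc(Oc5ccc(F)cc5)cc4)C3=O)c2)CC1`: 4430 nM

Both compounds were tested in an ADME assay on RAW264.7 cells (Mus musculus) for cytotoxicity, read by MTT assay, with a stated time of 24 h, in the presence of a further agent that is not named here; on this read-out higher numbers stand for weaker inhibition and lower numbers for stronger inhibition. For compound 1, > 10000 nM is a limit of the assay and not a number. Among the compounds with values here, that leaves compound 2, at 4430 nM, with the only true number available, so there is no measured spread of values against which to place it.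

Compound 3 `CN1CCN(CCCCCOc2cccc(N3C(=O)S/C(=C\c4ccc(Oc5ccc(Cl)cc5)cc4)C3=O)c2)CC1` is the next compound to be tested in this assay. It matches compound 2 except for one substitution: chloro in place of fluoro on an aromatic carbon. This puts chloro in place of fluoro on an aromatic carbon, para to a large group, turning 4-fluorophenoxy into 4-chlorophenoxy.

Within the data shown here, no measured pair of compounds differs in one place only, so the data give no direct guide to the size of this swap. With only this single substitution, the best starting point is compound 2 at 4430 nM, and no shift beyond the usual scatter of repeat measurements is expected. The expected change a 1.1-fold lower number from compound 2 to compound 3 (0.04 log units; within the scatter) is therefore small, in the direction of slightly stronger inhibition. For compound 3 the estimated value is 4000 nM, with an expected range of 1800 nM to 9000 nM.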

Compound 3, half-maximal inhibitory concentration: > 10000 nM
Compound 3 gave a limit, no number (the forecaster's own chance of this, stated with the estimate: 10%); middle value at least 2.5-fold (0.39 log units) from the limit.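

In this assay, within the data shown here, the only change between these two compounds, 4-fluorophenoxy to 4-chlorophenoxy, gives an at least 2.2-fold higher number from compound 2 to compound 3 (0.35 log units; beyond the scatter), so the read-out moves toward weaker inhibition of the cells. Among these compounds, this is the first direct evidence that the group at this place, on an aromatic carbon para to a large group, matters in this test: exchanging a single atom has an effect larger than the difference expected between repeated measurements. Compound 1 could not show this, since it differs from compound 2 in more than one place, and the size of the new step remains only a minimum because the result for compound 3 is a limit and not a number: the limit of > 10000 nM in this assay, at which 2 of the 3 values shown sit.

From the compounds shown here alone, how far the effect extends along a series at this place remains open, since a bromo, methyl or methoxy group there could show whether the read-out keeps moving in the same direction or returns toward that of compound 2. Among the compounds shown here, it is also unknown whether the fluoro-to-chloro change would have a similar effect on a compound with a longer chain than the one in compound 2 and compound 3.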